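The source may report more compounds than this note shows. Statements on the series, on what has been measured and on what is new or still open speak of the compounds shown alone.

Measured so far in a physicochemical assay for solubility, measured as kinetic solubility, with a stated time of 24 h, at pH 7.4; a lower number here means a less soluble compound, a higher number a more soluble compound:
compound 1 `O=C(NCc1ccc(S(=O)(=O)c2cc(F)cc(F)c2)cc1)c1cc2ccncc2o1`; compound 1 gives 5900 nM
compound 2 `CC(C)n1cc(S(=O)(=O)c2ccc(CNC(=O)c3cc4ccncc4o3)cc2)cn1`; compound 2 gives 12000 nM
compound 3 `O=C(NCc1ccc(S(=O)(=O)c2cc(F)cc(F)c2)cn1)c1cc2cnccc2[nH]1`; compound 3 gives 11000 nM

Compound 1 and compound 2 differ in one place: 1-isopropyl-1H-pyrazol-4-yl in place of 3,5-difluorophenyl on a sulfonyl sulfur. That single change gave a 2.0-fold higher number from compound 1 to compound 2 (0.31 log units; beyond the scatter). Compound 3 is built on a different core from compound 1; how the two cores differ is not broken down here, and the two values sit within the usual scatter of each other, so nothing is read from their gap. Compound 2 and compound 3 likewise lie within the scatter of each other.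

Compound 4 `CC(C)n1cc(S(=O)(=O)c2ccc(CNC(=O)c3cc4cnccc4[nH]3)nc2)cn1` has not yet been measured. It stands to compound 3 exactly as compound 2 stands to compound 1: the change is 1-isopropyl-1H-pyrazol-4-yl in place of 3,5-difluorophenyl on a sulfonyl sulfur, at the same place on the sulfonyl sulfur. Among the compounds shown this change occurs twice, measured once. Because that one measured instance gave a 2.0-fold higher number from compound 1 to compound 2 (0.31 log units; beyond the scatter), a step of similar size is expected on the core of compound 3. For compound 4 in this assay the expected number is 22000 nM, with a likely range from 11000 nM to 45000 nM. The expected step is a 2.0-fold higher number from compound 3 to compound 4 (0.30 log units; within the scatter), resting on that single precedent only.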

Compound 4, solubility: 46000 nM
The estimate for compound 4 lay 2.1-fold (0.32 log units) below the measured number, and the stated range ends below it.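

In this assay, 1-isopropyl-1H-pyrazol-4-yl in place of 3,5-difluorophenyl on a sulfonyl sulfur gave a 4.2-fold higher number from compound 3 to compound 4 (0.62 log units; beyond the scatter) on the core of compound 3, and the same change gave a 2.0-fold higher number from compound 1 to compound 2 (0.31 log units; beyond the scatter) on the core of compound 1, so the direction carried from one core to the other and neither pair goes against it. This is one pair on each of two cores, which supports the direction on these cores only and does not establish a fixed step size or show that the change would behave the same way on any other core. Nothing measured here accounts for the size of either step.

The compounds shown place only these two groups on the sulfonyl sulfur, and neither carries net charge. On these data alone, it remains open whether the direction would hold with an amine or a carboxylic acid on that group, or with a longer alkyl chain in place of the isopropyl.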